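The source may report more compounds than this note shows. Statements on the series, on what has been measured and on what is new or still open speak of the compounds shown alone.

Of the compounds shown here, three sharing one core have been measured in a functional assay on CHO-K1 cells for antagonist activity at transient receptor potential cation channel subfamily V member 1 (Homo sapiens), read by FLIPR; a lower number here means a stronger inhibitor, a higher number a weaker inhibitor. Compound 1 `CCCCNc1nc(C(F)(F)F)ccc1CNC(=O)C(C)c1ccc(NS(C)(=O)=O)c(F)c1` gives 293 nM; compound 2 `CC(C(=O)NCc1ccc(C(F)(F)F)nc1N1CCCC1)c1ccc(NS(C)(=O)=O)c(F)c1` gives 211 nM; compound 3 `CC(=O)OC1CCN(c2nc(C(F)(F)F)ccc2CNC(=O)C(C)c2ccc(NS(C)(=O)=O)c(F)c2)CC1` gives 139 nM. Compound 3 has the lowest of the three numbers: the step of a 1.5-fold lower number from compound 2 to compound 3 (0.18 log units; within the scatter) is within the scatter, while the step of a 2.1-fold lower number from compound 1 to compound 3 (0.32 log units; beyond the scatter) is beyond it, though modest.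

Compound 4 `CC(C(=O)NCc1ccc(C(F)(F)F)nc1N1CCCCCC1)c1ccc(NS(C)(=O)=O)c(F)c1` differs from compound 3 in one place: azepan-1-yl in place of 4-acetoxypiperidin-1-yl on an aromatic carbon. The measured steps that bear on this all change the same group on the same carbon. Among the compounds with values here, the step of a 1.4-fold lower number from compound 1 to compound 2 (0.14 log units; within the scatter), which brought in a ring of the same kind, and the step of a 1.5-fold lower number from compound 2 to compound 3 (0.18 log units; within the scatter) were both within the scatter; only the step of a 2.1-fold lower number from compound 1 to compound 3 (0.32 log units; beyond the scatter) went beyond it, and only modestly. Compound 4 carries a plain ring, as compound 2 does, so its number is expected to lie near that of compound 2, with an expected step of a 1.6-fold higher number from compound 3 to compound 4 (0.20 log units; within the scatter) that stays within the scatter. Compound 4 is therefore estimated at 220 nM, within a range from 90 nM to 550 nM.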

Compound 4, half-maximal inhibitory concentration: 25.1 nM
Beside the measured number, compound 4's estimate is 8.8-fold (0.94 log units) above it, outside the stated range (below it).
By their numbers in this assay, from the lowest: compound 4; then compounds 3, 2 and 1 (each within the scatter of the next, the first and the last beyond it).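

On the aromatic carbon next to the ring nitrogen, the earlier groups gave numbers close to one another in this assay, but azepan-1-yl stands apart from 4-acetoxypiperidin-1-yl (a 5.5-fold lower number from compound 3 to compound 4 (0.74 log units; beyond the scatter)), from pyrrolidin-1-yl (an 8.4-fold lower number from compound 2 to compound 4 (0.92 log units; beyond the scatter)) and from butylamino (a 12-fold lower number from compound 1 to compound 4 (1.07 log units; beyond the scatter)). Pyrrolidin-1-yl and azepan-1-yl are both plain rings joined through nitrogen, so being a plain ring is not enough to give the low number. This position therefore responds far more strongly to the exact group than the first three compounds suggested.

Still open, on these data alone, is whether the gain belongs to the seven-membered ring itself, which an unsubstituted piperidine ring, a morpholine ring or an azepane ring carrying a methyl group could test. Nothing available here explains why azepan-1-yl gives so much lower a number.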